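Quinolinyl amides on the shared core: compound 1 to compound 3

This account rests on a few compounds, and the source may have more. Where it says the series, first, only, none or still open, it means among the compounds named here.

Measured so far:
compound 1 `CCN1CCN(c2cc(C)c3cc(NC(=O)c4cccnc4)ccc3n2)CC1`: 26600 nM
compound 2 `Cc1cc(NCCN(C)C)nc2ccc(NC(=O)c3ccc(Cl)c(Cl)c3)cc12`: 2550 nM

In a functional assay on MCF7 cells (Homo sapiens) for antiproliferative activity, read by MTT assay, with a stated time of 72 h (a lower number here means a stronger inhibitor, a higher number a weaker inhibitor), compound 1 gives 26600 nM, the highest of the two numbers; compound 2 gives 2550 nM, a lower number well beyond the scatter. Going by the values given here, no pair of measured compounds differs in one place, so no measured step is known. Compound 3 `CCN1CCN(c2cc(C)c3cc(NC(=O)c4ccc5ccccc5n4)ccc3n2)CC1` differs from compound 1 in one place: quinolin-2-yl in place of pyridin-3-yl on a carbonyl carbon. Nothing measured bears directly on this change. A moderate step down from compound 1 to compound 3 is expected, a 2.7-fold lower number from compound 1 to compound 3 (0.42 log units; beyond the scatter), though it could also stay within the scatter. Compound 3 is therefore estimated at 10000 nM, within 2000 nM to 40000 nM.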

Compound 3, half-maximal inhibitory concentration: 7060 nM
For compound 3 the middle estimate is 1.4-fold (0.15 log units) above the measured one, and the stated range covers the measured number.
By their numbers in this assay, from the lowest: compound 2; then compound 3; then compound 1.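

In this assay, the group on a carbonyl carbon now has a measured effect: quinolin-2-yl in place of pyridin-3-yl gives a 3.8-fold lower number from compound 1 to compound 3 (0.58 log units; beyond the scatter), with the rest of compound 1 unchanged. The change adds a six-membered aromatic ring of carbon only, while the hydrogen-bond donor and acceptor counts stay the same. No measurement at hand explains this step.

As far as these compounds go, whether the lower number follows the added ring or the ring nitrogen remains open. A naphthalen-2-yl or phenyl group on the same carbonyl carbon would separate the two.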